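This account rests on a few compounds, and the source may have more. Where it says the series, first, only, none or still open, it means among the compounds named here.

Compound 1 `COc1cc(-c2nn(-c3cccc(NC(=O)c4ccc(Cl)c(C(F)(F)F)c4)c3)cc2-c2ccncc2)ccc1Cl` was examined in a functional assay on SF-268 cells (Homo sapiens) for inhibition, read by sulforhodamine B assay, with a stated time of 48 h; on this read-out higher numbers stand for lower toxicity in this test and lower numbers for higher toxicity in this test. In this test compound 1 gives only a limit, > 32500 nM, so no number is known for it. A second compound, compound 2 `O=C(Nc1cccc(-n2cc(-c3ccncc3)c(-c3ccc(Cl)c(O)c3)n2)c1)Nc1cc(C(F)(F)F)cc(C(F)(F)F)c1`, built on a related core, gives 20500 nM in this assay. Compound 3 `COc1cc(-c2nn(-c3cccc(NC(=O)Nc4cccc(C(F)(F)F)c4)c3)cc2-c2ccncc2)ccc1Cl` has not yet been measured. Compared with compound 1 it carries (3-(trifluoromethyl)phenyl)amino in place of 4-chloro-3-(trifluoromethyl)phenyl on a carbonyl carbon. Because compound 1 sits at the limit of > 32500 nM in this assay, at which 1 of the 2 values shown sits, no direction of change can be read from compound 1 alone; the value of compound 2 shows that a member of this series can give a number not far from that limit. The step of an at least 1.0-fold lower number from compound 1 to compound 3 (0.03 log units; that floor lies within the scatter) is therefore expected to be small, with no clear direction beyond the usual scatter. Compound 3 is estimated at 30000 nM, in a range from 15000 nM to 60000 nM, with a fair chance that this assay again reports only a limit.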

Compound 3, concentration lethal to 50% of the cells: 50000 nM
Compound 3: middle estimate off by 1.7-fold (0.22 log units), on the low side; measured number inside the range.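

No step from compound 1 to compound 3 can be read, because compound 1 gives only a limit: the limit of > 32500 nM in this assay, at which 1 of the 3 values shown sits.

The compounds shown leave open whether (3-(trifluoromethyl)phenyl)amino in place of 4-chloro-3-(trifluoromethyl)phenyl on a carbonyl carbon changes the read-out at all, and in which direction.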